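The source may report more compounds than this note shows. Statements on the series, on what has been measured and on what is new or still open speak of the compounds shown alone.

Three compounds share one core and differ only in the group on the benzene ring. Compound 1 `C/C(=C\c1cc(-c2ccc(C)cc2)cs1)C(N)=O` was tested in a functional assay on A549 cells (Homo sapiens) for cytotoxicity, read by CCK-8 assay, with a stated time of 24 h (on this read-out higher numbers stand for weaker inhibition and lower numbers for stronger inhibition), and its result there is a limit, > 50000 nM. Compound 2 `C/C(=C\c1cc(-c2ccc(S(C)(=O)=O)cc2)cs1)C(N)=O` also reaches only a limit in this assay, > 50000 nM. Compound 3 `C/C(=C\c1cc(-c2ccc(Cl)cc2)cs1)C(N)=O` likewise gives a limit in this assay, > 50000 nM. Because all three values sit at the limit of > 50000 nM in this assay, at which 3 of the 3 values shown sit, the steps between them cannot be read: a step that the two limits leave unreadable from compound 1 to compound 2, a step that the two limits leave unreadable from compound 1 to compound 3 and a step that the two limits leave unreadable from compound 2 to compound 3. Compound 4 `C=Cc1ccc(-c2csc(/C=C(\C)C(N)=O)c2)cc1` differs from compound 3 by vinyl in place of chloro on an aromatic carbon. With every measured step unreadable, no shift beyond the scatter can be expected, and the step that the limit leaves unreadable from compound 3 to compound 4 is only an estimate. Compound 4 is therefore expected to give about 100000 nM, within 40000 nM to 300000 nM, most likely again reported as a limit.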

Compound 4, half-maximal inhibitory concentration: > 50000 nM
Compound 4 was reported as a limit (the forecaster's own chance of this, stated with the estimate: 85%); the middle value does not contradict the limit.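

Compound 4 also gives only a limit, so its steps to compound 1, compound 2 and compound 3 cannot be read: the limit of > 50000 nM in this assay, at which 4 of the 4 values shown sit. In this assay the compounds shown leave open whether any other group on the benzene ring would give a measured value rather than a limit.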